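The compounds below may be only part of what the source reports. "The series", "measured", "known", "first", "only" and "open" are said of these compounds alone.

Series notes, tolerability on the shared core. In an ADME assay on Vero cells (Chlorocebus sabaeus) for cytotoxicity, read by resazurin assay, with a stated time of 2 days (a higher number here means that more compound is tolerated, a lower number that less compound is tolerated), compound 1 `CC(=O)OC[C@H]1O[C@@H](CC(=O)/C=C/c2cccc(NC(=O)Nc3ccccc3)c2)[C@@H](OC(C)=O)[C@@H](OC(C)=O)[C@@H]1OC(C)=O` gives 102000 nM, compound 2 `CC(=O)OC[C@H]1O[C@@H](CC(=O)/C=C/c2cccc(NC(=S)Nc3ccccc3)c2)[C@H](OC(C)=O)[C@@H](OC(C)=O)[C@@H]1OC(C)=O` gives 337000 nM, and compound 3 `CC(=O)OC[C@H]1O[C@@H](CC(=O)/C=C/c2cccc(NS(=O)(=O)c3ccc(C)cc3)c2)[C@@H](OC(C)=O)[C@@H](OC(C)=O)[C@@H]1OC(C)=O` gives 123000 nM. Compound 3 thus stands second highest of the three, close to compound 1 and well below compound 2. For the measured compounds named here, the one measured single change, a 1.2-fold higher number from compound 1 to compound 3 (0.08 log units; within the scatter), is within the scatter. Compound 4 `CC(=O)OC[C@H]1O[C@@H](CC(=O)/C=C/c2cccc(NC(=S)Nc3ccccc3)c2)[C@@H](OC(C)=O)[C@@H](OC(C)=O)[C@@H]1OC(C)=O` differs from compound 3 by a group of 9 heavy atoms (7 carbon, 1 nitrogen, 1 sulfur; one six-membered aromatic ring of carbon only) in place of a group of 10 heavy atoms (7 carbon, 2 oxygen, 1 sulfur; one six-membered aromatic ring of carbon only), on a nitrogen on an aromatic ring. Going by the values given here, no measured step covers this exact exchange, and no single-change step connects compound 2 to compound 4, so only the small, flat step from compound 1 to compound 3 bears on it. For compound 4 in this assay a step of a 1.6-fold higher number from compound 3 to compound 4 (0.21 log units; within the scatter) is expected, with the estimate 200000 nM and a range of 80000 nM to 500000 nM.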

Compound 4, half-maximal cytotoxic concentration: 65100 nM
The estimate for compound 4 lay 3.1-fold (0.49 log units) above the measured number; the measured number lies below the stated range.
By their numbers in this assay, from the lowest: compounds 4, 1 and 3 (each within the scatter of the next); then compound 2.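

In this assay, for the compounds shown here, a change of configuration alone gives a 5.2-fold lower number from compound 2 to compound 4 (0.71 log units; beyond the scatter), the first single change beyond the scatter, and it rests on one stereocentre at a saturated ring carbon: the fact that compounds 2 and 4 differ only in the configuration as drawn. On the nitrogen on an aromatic ring, the exchanges stay flat, with a 1.9-fold lower number from compound 3 to compound 4 (0.28 log units; within the scatter) and a 1.6-fold lower number from compound 1 to compound 4 (0.20 log units; within the scatter). At this configuration, the group in compound 4 does not separate from phenylcarbamoyl or (4-methylphenyl)sulfonyl.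

As far as these compounds go, whether the same configuration change shifts the number with those two groups stays open. So does the effect of a carboxylic acid or a longer alkyl chain on that nitrogen.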